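Adding a Second Methoxy Group to Compound 1

This account rests on a few compounds, and the source may have more. Where it says the series, first, only, none or still open, it means among the compounds named here.

Going by the values given here, compound 1 `COc1ccc(-c2cc(/C=C/C(=O)c3ccc(N)cc3)[nH]n2)cc1` is the only member of this set with a numerical result. In a functional assay on DU-145 cells (Homo sapiens) for inhibition, read by sulforhodamine B assay, with a stated time of 48 h (a higher number here means a weaker inhibitor of growth, a lower number a stronger inhibitor of growth), compound 1 gives 1320 nM, so on the numbers shown it stands alone, with nothing to rank it against. Compound 2 `COc1cc(-c2cc(/C=C/C(=O)c3ccc(Cl)c(Cl)c3)[nH]n2)cc(OC)c1OC` belongs to the same series, but in this assay compound 2 gives "not determined" (no result reported), which leaves no number to compare. Compound 3 `COc1ccc(-c2cc(/C=C/C(=O)c3ccc(N)cc3)[nH]n2)cc1OC` has not been measured. It differs from compound 1 by methoxy in place of hydrogen on an aromatic carbon. Among the compounds with values here, no step between two measured compounds shows how such a change plays out here, so any expectation rests on compound 1 alone. The expected step, a 1.2-fold lower number from compound 1 to compound 3 (0.08 log units; within the scatter), is small and carries no clear direction beyond the usual scatter. In this assay compound 3 is therefore estimated at 1100 nM, within a range from 300 nM to 4000 nM.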

Compound 3, concentration for 50% growth inhibition: 3740 nM
For compound 3 the middle estimate is 3.4-fold (0.53 log units) below the measured one, within the range that was stated.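

Methoxy in place of hydrogen on an aromatic carbon, ortho to a methoxy group and meta to a large group, gives in this assay a 2.8-fold higher number from compound 1 to compound 3 (0.45 log units; beyond the scatter) and so moves the read-out toward a weaker inhibitor of growth. Going by these compounds alone, this is the only step that can be read in the set, and it shows that this change at this position does not leave the number where it stood. Nothing measured here speaks to why the number moves.

On these data alone, whether the step belongs to methoxy itself or would also appear with a hydroxy group, a fluorine atom or an ethoxy group at the same place stays open. The compounds shown also leave open whether the same change would give a similar step with a group other than the amine on the far aromatic ring.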